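Swapping a Methoxy for Hydrogen at the Assay Limit

The source may hold more compounds than are shown below. What is called first, only, known or untested is meant among the compounds shown, and "the series" means these compounds.

Two related compounds have been tested so far, compound 1 `COc1ccc2c(C(=O)/C(C#N)=C/c3cn(Cc4ccc(Cl)cc4)c4ccccc34)c[nH]c2c1` and compound 2 `COc1ccc2c(C(=O)/C(C#N)=C/c3c[nH]c4ccc(OC)cc34)c[nH]c2c1`. In a functional assay on MIA PaCa-2 cells (Homo sapiens) for cytotoxicity, read by WST assay, with a stated time of 24 h (on this read-out lower numbers stand for stronger inhibition and higher numbers for weaker inhibition), compound 1 gives > 50000 nM, which is a limit of the assay and not a number. In this assay, compound 2 gives > 50000 nM, and this too is only a limit. The overall picture is therefore (the limit of > 50000 nM in this assay, at which 2 of the 2 values shown sit). For the measured compounds named here, compound 2 thus has no exact value, and no measured pair shows what a single structural change does here.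

The next molecule, compound 3 `COc1ccc2c(C(=O)/C(C#N)=C/c3c[nH]c4ccccc34)c[nH]c2c1`, differs from compound 2 in one place: hydrogen in place of methoxy on an aromatic carbon. Hydrogen stands in place of methoxy on an aromatic carbon, and the rest of the molecule stays the same. Going by the values given here, with no measured step to guide the expectation, no change beyond the usual scatter is expected in this assay, and neither direction is favoured. The expected step is a number no higher from compound 2 to compound 3 (the limit leaves the size open). For compound 3, the estimated value is 50000 nM, with an expected range from 15000 nM to 100000 nM.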

Compound 3, half-maximal inhibitory concentration: 13500 nM
Beside the measured number, compound 3's estimate is 3.7-fold (0.57 log units) above it, and the stated range ends above it.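

In this assay, hydrogen in place of methoxy on an aromatic carbon gives an at least 3.7-fold lower number from compound 2 to compound 3 (0.56 log units; beyond the scatter), so this position, on a six-membered aromatic ring of carbon only, can change the read-out in this series. Hydrogen in place of 4-chlorobenzyl on an aromatic nitrogen gives an at least 3.7-fold lower number from compound 1 to compound 3 (0.56 log units; beyond the scatter), which shows that a second site in the molecule also matters, and compound 3, which carries neither of these groups, is the only compound shown with an exact number. Both steps start from a limit of the assay and not from a number, so their true sizes stay open: the limit of > 50000 nM in this assay, at which 2 of the 3 values shown sit.

The compounds shown leave open whether only hydrogen gives a measurable value at that aromatic carbon, or whether a fluorine, a hydroxyl or an amine there would do the same. They also leave open whether a methyl group on the aromatic nitrogen would read like the hydrogen of compound 3 or like the 4-chlorobenzyl of compound 1.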